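Trading a Methoxy for a Hydroxy on Compound 3

The compounds below may be only part of what the source reports. "The series", "measured", "known", "first", "only" and "open" are said of these compounds alone.

Three compounds have been measured in a functional assay on HCT-116 cells (Homo sapiens) for inhibition, read by sulforhodamine B assay, with a stated time of 48 h; on this read-out lower numbers stand for stronger inhibition of growth and higher numbers for weaker inhibition of growth:
compound 3 `COc1cc(C)cc(-c2nn(CC#N)cc2-c2ccnc(-c3ccc(N(C)C)cc3)c2)c1` gives 353 nM
compound 2 `Cc1cc(O)cc(-c2nn(CC#N)cc2-c2ccnc(-c3ccc(Oc4ccccc4)cc3)c2)c1` gives 1560 nM
compound 1 `COc1cc(C)cc(-c2nn(CC#N)cc2-c2ccc(-c3cccc(C(C)=O)c3)nc2)c1` gives 2330 nM

Compound 3 has the lowest number of the three, and its gaps to compound 2 and to compound 1 both lie beyond the usual scatter of this assay. Compound 4 `Cc1cc(O)cc(-c2nn(CC#N)cc2-c2ccnc(-c3ccc(N(C)C)cc3)c2)c1` differs from compound 3 in one place: hydrogen in place of methyl on an oxygen on an aromatic ring. Among the measured compounds shown here, no measured pair shows this change on its own, so there is no direct guide to its size. The expected step is a 1.2-fold higher number from compound 3 to compound 4 (0.08 log units; within the scatter), most likely within the scatter in either direction. Compound 4 is therefore estimated at 420 nM, with a range from 150 nM to 1200 nM.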

Compound 4, concentration for 50% growth inhibition: 2710 nM
The estimate for compound 4 lay 6.5-fold (0.81 log units) below the measured number; measured number outside the range, above it.
By their numbers in this assay, from the lowest: compound 3; then compounds 2, 1 and 4 (each within the scatter of the next).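

Replacing methoxy with hydroxy on the ring of compound 3 matters in this assay (the change gives a 7.7-fold higher number from compound 3 to compound 4 (0.89 log units; beyond the scatter)). With hydroxy held in place, dimethylamino in place of phenoxy shows no clear effect (the change gives a 1.7-fold higher number from compound 2 to compound 4 (0.24 log units; within the scatter)), so on this pair the methoxy-to-hydroxy change carries a large effect while the other change does not. Nothing measured here offers a reason for the large step.

On these data alone, whether ethoxy or an amino group in place of methoxy would keep the number near that of compound 3 remains open. So does the size of the same methoxy-to-hydroxy change when phenoxy replaces dimethylamino.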